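The compounds below may be only part of what the source reports. "The series", "measured", "known", "first", "only" and "open" are said of these compounds alone.

Values so far in an ADME assay on L6 cells (Rattus norvegicus) for inhibition, read by resazurin assay, with a stated time of 72 h (a lower number here means a stronger inhibitor, a higher number a weaker inhibitor), for the series

- compound 1 `CSC[C@H]1O[C@@H](n2cnc3c(N)nc(F)nc32)[C@H](OC(C)=O)[C@@H]1OC(C)=O` gives 15000 nM in this read-out
- compound 2 `CC(=O)O[C@@H]1[C@H](OC(C)=O)[C@@H](CN=[N+]=[N-])O[C@H]1n1cnc2c(N)nc(F)nc21` gives 18000 nM in this read-out

Compound 2 at 18000 nM stands level with compound 1 within the scatter, so the two values give no order. Next comes compound 3 `CC(=O)NC[C@H]1O[C@@H](n2cnc3c(N)nc(F)nc32)[C@H](OC(C)=O)[C@@H]1OC(C)=O` and its difference from compound 2 is acetamido in place of azido on a saturated chain carbon bound to a saturated ring carbon in all: acetamido in place of azido on a saturated chain carbon bound to a saturated ring carbon. Among the measured compounds shown here, one measured step bears on this place, azido in place of methylsulfanyl, and a 1.2-fold higher number from compound 1 to compound 2 (0.08 log units; within the scatter) stays within the scatter. For the measured compounds named here, no measured compound carries acetamido, so this single step is thin support. In this assay no step beyond the scatter is expected. The expected change is a 1.4-fold higher number from compound 2 to compound 3 (0.14 log units; within the scatter) on this basis. For compound 3 the estimated value is 25000 nM with an expected range from 8000 nM to 70000 nM in this read-out.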

Compound 3, half-maximal inhibitory concentration: 138000 nM
Estimate against measurement, compound 3: 5.5-fold (0.74 log units) below, outside the stated range (above it).
By their numbers in this assay, from the lowest: compounds 1 and 2 (each within the scatter of the next); then compound 3.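

At the saturated chain carbon bound to a saturated ring carbon, this assay proves sensitive to the group carried there, which the azido and methylsulfanyl pair could not show. Acetamido gives a 7.7-fold higher number from compound 2 to compound 3 (0.88 log units; beyond the scatter) and, measured against methylsulfanyl, a 9.2-fold higher number from compound 1 to compound 3 (0.96 log units; beyond the scatter) and so leaves compound 3 as the weakest inhibitor of the three, with a hydrogen-bond donor that azido lacks and a similar size in heavy atoms. Nothing at hand says what lies behind this shift.

On these data alone, whether the amide hydrogen, the carbonyl or the added methyl carries the step stays open, since acetamido changes all of them together. A primary amine, a carboxylic acid or a longer acyl chain at this place would help separate these parts, and three compounds on one shared core set no trend beyond themselves.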